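The source may report more compounds than this note shows. Statements on the series, on what has been measured and on what is new or still open speak of the compounds shown alone.

Working notes on the series. Compound 1 `CC1=C(C(=O)OC2CCCCC2)C(c2ccco2)NC(=O)N1` carries a cyclohexyl ester and a furan-2-yl group, and in an assay on membranes from HeLa cells for displacement of a labelled ligand from adenosine receptor A3 (Homo sapiens), read by scintillation counting, with a stated time of 180 min, tested at 1 uM (on this read-out lower numbers stand for less inhibition and higher numbers for more inhibition at the one concentration tested (going by the name of the read-out)), compound 1 gives 4%. Compound 2 `CC1=C(C(=O)OCC2CC2)C(c2ccco2)NC(=O)N1` differs from compound 1 in one place, (cyclopropylmethyl in place of cyclohexyl on an oxygen next to a carbonyl group), and in this assay compound 2 gives 1%; the step is a number 3 percentage points lower from compound 1 to compound 2 (within the scatter). Compound 3 `CC1=C(C(=O)OC2CCCCC2)C(c2ccoc2)NC(=O)N1` keeps the cyclohexyl ester of compound 1, the two cores differing as furan-3-yl in place of furan-2-yl on a saturated ring carbon, and in this assay compound 3 gives 1%; that step is a number 3 percentage points lower from compound 1 to compound 3 (within the scatter). Compound 2 and compound 3 show no change at the digits read.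

Compound 4 `CC1=C(C(=O)OCC2CC2)C(c2ccoc2)NC(=O)N1` has not yet been measured in this assay. It differs from compound 3 by cyclopropylmethyl in place of cyclohexyl on an oxygen next to a carbonyl group, the same change, at the same place in the same words, that leads from compound 1 to compound 2; this change occurs twice among the four compounds. Compound 3 sits at 1% and the earlier step of a number 3 percentage points lower from compound 1 to compound 2 (within the scatter) lay within the scatter. On that basis the change to compound 4 is expected to be a step of no change at the digits printed from compound 3 to compound 4 (within the scatter). Compound 4 is expected to give about 1% in this assay, with a range from -5% to 8%.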

Compound 4, a percentage reported as inhibition, at one concentration (the size of the read-out at that concentration, not a potency): 3%
The estimate for compound 4 lay 2 percentage points below the measured number; measured number inside the range.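

In this assay the ester change on the furan-3-yl core appears as a number 2 percentage points higher from compound 3 to compound 4 (within the scatter) and, set beside the same change on the furan-2-yl core, shows no difference between the two cores: the same change on two cores in this assay, a number 3 percentage points lower (within the scatter) from compound 1 to compound 2 and a number 2 percentage points higher (within the scatter) from compound 3 to compound 4, 5 percentage points apart, within the scatter of two such steps.
The furan change, carried onto the cyclopropylmethyl ester, appears as a number 2 percentage points higher from compound 2 to compound 4 (within the scatter) and likewise agrees with its counterpart on the cyclohexyl ester: the same change on two cores in this assay, a number 3 percentage points lower (within the scatter) from compound 1 to compound 3 and a number 2 percentage points higher (within the scatter) from compound 2 to compound 4, 5 percentage points apart, within the scatter of two such steps.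
Among these compounds, this shows that neither change produced a step beyond the scatter on either core, but it does not show that either change carries a real, transferable effect, since no step here stands out from the scatter and a reading at one concentration gives no potency.

Still open, on these data alone, is whether any group outside cyclohexyl, cyclopropylmethyl and the two furans, such as a longer alkyl chain on the ester oxygen or a phenyl ring on the saturated ring carbon, would lift the number clear of the scatter. As far as these compounds go, an amide or a carboxylic acid in place of the ester also remains open.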